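Swapping an indole for a fluorophenyl on a pyridone amide

This account rests on a few compounds, and the source may have more. Where it says the series, first, only, none or still open, it means among the compounds named here.

The measured compounds, with their results in a physicochemical assay for lipophilicity, at pH 7.4; a higher number here means a more lipophilic compound, a lower number a more polar compound:

- compound 1, `CNC(=O)c1cc(C(=O)NC2CC2)cn(Cc2cccc3[nH]c(C)nc23)c1=O`, gives 1.5
- compound 2, `CNC(=O)c1cc(C(=O)NC2CC2)cn(Cc2cccc3cc[nH]c23)c1=O`, gives 3.7
- compound 3, `CCNC(=O)c1cccn(Cc2ccccc2)c1=O`, gives 3.7

Compound 2 stands level with compound 3 at the digits shown, and the two together sit at the top of the three numbers; the gap between them lies within the scatter. Compound 1 is the furthest away, a good deal lower than compound 2, and that gap is beyond the scatter.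

The unmeasured compound 4, `CNC(=O)c1cc(C(=O)NC2CC2)cn(Cc2cccc(F)c2)c1=O`, is reached from compound 2 by one change: 3-fluorophenyl in place of 1H-indol-7-yl on a saturated chain carbon bound to an aromatic nitrogen. A fused two-ring group carrying one hydrogen-bond donor leaves, and a single ring carrying a fluorine enters. Within the data shown here, no measured pair shows this change, so its effect on this assay is not known from the data here. The step is expected to be small, perhaps slightly downward, and most likely within the scatter, as a number 0.10 log units lower from compound 2 to compound 4 (within the scatter). Compound 4 is therefore expected to give about 3.6, within a range from 2.9 to 4.3.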

Compound 4, distribution coefficient: 3.2
For compound 4 the middle estimate is 0.40 log units above the measured one; the range from low to high includes it.
By their numbers in this assay, from the lowest: compound 1; then compound 4; then compounds 2 and 3 (each within the scatter of the next).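

On a saturated chain carbon bound to an aromatic nitrogen, 3-fluorophenyl in place of 1H-indol-7-yl gives, in this assay, a number 0.50 log units lower from compound 2 to compound 4 (beyond the scatter). Among these compounds, this is the only measured pair here with the core held fixed and this one group exchanged, and it shows that the reading responds to the group at this position. The change swaps a fused two-ring group carrying a hydrogen-bond donor for a single ring carrying a fluorine, and nothing available shows which of these differences accounts for the step.

A plain phenyl at the same place would help to separate the loss of the second ring from the arrival of the fluorine, but the compounds shown leave its value open. Also open, going by these compounds, is how an amine or a carboxylic acid on that ring would read.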